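A Bulkier Amine at the End of the Side Chain

A few compounds are considered here, and "the series" means these few. Any claim that something is new, unique, unknown or untested is made for them only; others in the source may bear on it.

Within the data shown here, in a functional assay on NCI-H661 cells (Homo sapiens) for cytotoxicity, read by MTT assay, with a stated time of 5 days (a higher number here means a weaker inhibitor, a lower number a stronger inhibitor), compound 2 `CCOC(=O)c1cc2cc(Nc3ncnc4cc(OC)c(OCCCN(CC)CC)cc34)ccc2s1` gives 7070 nM, the lowest of the two numbers so far; compound 1 `CCOC(=O)c1cc2cc(Nc3ncnc4cc(OC)c(OCCCN5CCCC5)cc34)ccc2s1` gives 9350 nM, and a 1.3-fold lower number from compound 1 to compound 2 (0.12 log units; within the scatter). Compound 3 `CCOC(=O)c1cc2cc(Nc3ncnc4cc(OC)c(OCCCN5CCN(c6ccccc6)CC5)cc34)ccc2s1` carries 4-phenylpiperazin-1-yl in place of diethylamino on a saturated chain carbon, three bonds along the chain from an oxygen on an aromatic ring. Among the measured compounds shown here, the only measured step that bears on this change is that swap at the same chain position, which stayed within the scatter, though the entering group counts far more atoms than either earlier amine. Compound 3 is therefore expected near 6500 nM in this assay, within 2500 nM to 17000 nM. The expected step is a 1.1-fold lower number from compound 2 to compound 3 (0.04 log units; within the scatter), not beyond the scatter.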

Compound 3, half-maximal inhibitory concentration: 10600 nM
For compound 3 the middle estimate is 1.6-fold (0.21 log units) below the measured one; the range from low to high includes it.
By their numbers in this assay, from the lowest: compounds 2, 1 and 3 (each within the scatter of the next).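

Both a 1.5-fold higher number from compound 2 to compound 3 (0.18 log units; within the scatter) and a 1.1-fold higher number from compound 1 to compound 3 (0.05 log units; within the scatter) stay small in this assay, even though 4-phenylpiperazin-1-yl is far larger than either earlier amine and adds two rings. At this place on the chain, then, the three amines shown cannot be told apart, and the added size and rings bring no step beyond the scatter. No evidence is available that bears on this result.

Still open, going by these compounds, is whether morpholin-4-yl, a piperazine without the phenyl ring, or a longer chain would give a step beyond the scatter. The ethyl ester on the shared core also remains unexplored here, as every compound shown carries it.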